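This account rests on a few compounds, and the source may have more. Where it says the series, first, only, none or still open, it means among the compounds named here.

Measured so far:
compound 1 `CC(=O)N1CC2CC(C1)N2`, in an assay on SH-EP1 cells for agonist activity at Neuronal acetylcholine receptor; alpha4/beta2 (Homo sapiens), read by FLIPR and calcium flux (a higher number here means that more compound is needed for the effect, a lower number that less compound is needed), compound 1 gives 9700 nM
compound 2 `CCCC(=O)N1CC2CC(C1)N2`, compound 2 gives 850 nM
compound 3 `O=C([C@@H]1C[C@@H]1F)N1CC2CC(C1)N2`, compound 3 gives 370 nM

All three share the same core and differ only in the group on the carbonyl carbon. The steps toward the third one are a 26-fold lower number from compound 1 to compound 3 (1.42 log units; beyond the scatter) and a 2.3-fold lower number from compound 2 to compound 3 (0.36 log units; beyond the scatter), both beyond the scatter, so compound 3 stands lowest of the three numbers.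

Compound 4 `C[C@@H]1C[C@H]1C(=O)N1CC2CC(C1)N2` has not yet been measured. It differs from compound 3 in one place: 2-methylcyclopropyl in place of 2-fluorocyclopropyl on a carbonyl carbon.

For the measured compounds named here, no measured step swaps fluorine for methyl on such a group. Going by the values given here, the steps that bear on it are an 11-fold lower number from compound 1 to compound 2 (1.06 log units; beyond the scatter) and a 26-fold lower number from compound 1 to compound 3 (1.42 log units; beyond the scatter), which show that going from methyl to a longer or cyclic group on the carbonyl carbon lowers the number a lot, and a 2.3-fold lower number from compound 2 to compound 3 (0.36 log units; beyond the scatter), a modest step. The group in compound 4 is again a three-membered non-aromatic ring of carbon only, so only a small step, a 1.2-fold higher number from compound 3 to compound 4 (0.09 log units; within the scatter), is expected, likely within the scatter. Compound 4 is therefore estimated at about 450 nM, in the range 150 nM to 1300 nM.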

Compound 4, half-maximal effective concentration: 2900 nM
Compound 4: the middle estimate sits 6.4-fold (0.81 log units) below what was measured; the whole stated range lies below it.
By their numbers in this assay, from the lowest: compound 3; then compound 2; then compound 4; then compound 1.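

In this assay the three-membered ring and the count of heavy atoms stay the same while methyl replaces fluorine on the ring, yet the number still moves by a large margin, with a 7.8-fold higher number from compound 3 to compound 4 (0.89 log units; beyond the scatter); the ring alone therefore does not set the number, and what it carries matters. A ring on the carbonyl carbon also offers no general gain over an open chain: compound 3 lies below propyl-bearing compound 2, whereas 2-methylcyclopropyl goes the other way, with a 3.4-fold higher number from compound 2 to compound 4 (0.53 log units; beyond the scatter), and still keeps part of the gain over the methyl of compound 1, with a 3.3-fold lower number from compound 1 to compound 4 (0.52 log units; beyond the scatter). Nothing available explains the gap between fluorine and methyl on this ring.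

Where plain cyclopropyl would fall relative to compound 3 and compound 4 remains open. So does the outcome for other ring substituents, such as chlorine or hydroxyl, and for other stereoisomers of these two rings.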